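Replacing 2-carboxy-1H-indol-5-yl with 1H-indol-4-yl

A few compounds are considered here, and "the series" means these few. Any claim that something is new, unique, unknown or untested is made for them only; others in the source may bear on it.

Among the measured compounds shown here, in a functional assay on DU-145 cells (Homo sapiens) for inhibition, read by trypan blue exclusion, with a stated time of 72 h (on this read-out lower numbers stand for stronger inhibition and higher numbers for weaker inhibition), only two compounds have numbers so far. Compound 1 (`Cn1c(=O)c(S(=O)(=O)c2ccc(F)cc2F)cc2cnc(Nc3ccc4[nH]c(C(=O)O)cc4c3)nc21`) gives 10000 nM in this read-out, and compound 2 (`Cn1c(=O)c(C(=O)Nc2ccc(F)cc2F)cc2cnc(Nc3ccc4[nH]ccc4c3)nc21`) gives 5000 nM on the same scale. These two values lie within the usual scatter of each other, so the data do not separate compound 1 from compound 2.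

Compound 3 (`Cn1c(=O)c(S(=O)(=O)c2ccc(F)cc2F)cc2cnc(Nc3cccc4[nH]ccc34)nc21`) carries 1H-indol-4-yl in place of 2-carboxy-1H-indol-5-yl on a nitrogen on an aromatic ring, and the rest of compound 1 stays unchanged. For the measured compounds named here, no measured pair shows this change on its own, so the data offer no direct guide to its size. A moderate step toward lower numbers in this assay is nonetheless expected, just beyond the scatter, although this expectation has little support and a result close to compound 1 remains possible. As an estimate, the expected change runs a 4.0-fold lower number from compound 1 to compound 3 (0.60 log units; beyond the scatter) and carries wide uncertainty. For compound 3 the expected value is 2500 nM with an estimated range from 500 nM to 10000 nM in this read-out.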

Compound 3, half-maximal inhibitory concentration: 750 nM
Beside the measured number, compound 3's estimate is 3.3-fold (0.52 log units) above it; measured number inside the range.
By their numbers in this assay, from the lowest: compound 3; then compounds 2 and 1 (each within the scatter of the next).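

In this assay, the exchange of 2-carboxy-1H-indol-5-yl for 1H-indol-4-yl on a nitrogen on an aromatic ring gives a 13-fold lower number from compound 1 to compound 3 (1.12 log units; beyond the scatter), a large step. Compounds 1 and 2 differ in more than one place and lie within the scatter of each other, so they gave no sign that this position matters; this single change now shows that inhibition in this read-out depends strongly on the group carried there. Among the compounds shown here, the data show only that the step occurs and give no explanation for its size, as nothing measured here bears on its cause.

The step combines two differences, the loss of the carboxy group and the move of the attachment point from the 5-yl to the 4-yl form of the group, and the compounds shown leave open how much each contributes; 2-carboxy-1H-indol-4-yl on the same nitrogen of the core of compound 1 would help to divide them. Also open, going by these compounds, is whether other groups at this place, such as a methyl ester or an amine on the 1H-indol-4-yl group, would keep the lower number seen for compound 3.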